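A few compounds are considered here, and "the series" means these few. Any claim that something is new, unique, unknown or untested is made for them only; others in the source may bear on it.

Measured so far in a functional assay on HepG2 cells (Homo sapiens) for cytotoxicity, read by MTT assay, with a stated time of 48 h; a higher number here means a weaker inhibitor, a lower number a stronger inhibitor:
Compound 1 `COc1cc(/C=C2/S/C(=N/c3ccccc3)N(Cc3ccncc3)C2=O)ccc1O` gives 28600 nM
Compound 2 `O=C1/C(=C\c2cccc(O)c2)S/C(=N/c2ccccc2)N1Cc1ccncc1` gives 17600 nM

These two values lie within the scatter of each other, so compound 2 stands level with compound 1 and neither can be ranked. Compound 3 `O=C1/C(=C\c2ccccn2)S/C(=N/c2ccccc2)N1Cc1ccncc1` differs from compound 2 in one place, by pyridin-2-yl in place of 3-hydroxyphenyl on a double-bonded chain carbon bound to a double-bonded ring carbon which puts pyridin-2-yl in place of 3-hydroxyphenyl on a double-bonded chain carbon bound to a double-bonded ring carbon. For the measured compounds named here, the only measured step touches that same place: it is a 1.6-fold lower number from compound 1 to compound 2 (0.21 log units; within the scatter) with 3-hydroxyphenyl in place of 4-hydroxy-3-methoxyphenyl. Going by the values given here, no measured compound carries pyridin-2-yl there, so this step is indirect guidance only. No shift beyond the scatter, in either direction, is therefore expected in this assay here. The expected step is a 1.3-fold higher number from compound 2 to compound 3 (0.10 log units; within the scatter) and it remains an estimate. Compound 3 is estimated at 22000 nM with 9000 nM to 50000 nM as the expected range.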

Compound 3, half-maximal inhibitory concentration: 31000 nM
For compound 3 the middle estimate is 1.4-fold (0.15 log units) below the measured one; the range from low to high includes it.
By their numbers in this assay, from the lowest: compounds 2, 1 and 3 (each within the scatter of the next).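

Pyridin-2-yl puts a six-membered aromatic ring with a hetero atom and 0 hydrogen-bond donors on the double-bonded chain carbon, yet this assay still does not separate it from the hydroxyphenyl groups: the data give a 1.8-fold higher number from compound 2 to compound 3 (0.25 log units; within the scatter) and a 1.1-fold higher number from compound 1 to compound 3 (0.03 log units; within the scatter). Among these three compounds, then, neither a hydrogen-bond donor on this group nor a ring of carbon only is required for the number to stay in this range. Nothing available here explains this result.

All three groups at this place are six-membered aromatic rings, and all three values lie within the scatter of one another. Going by these compounds, whether an amine, a carboxylic acid or a longer chain on the double-bonded chain carbon would move the number beyond the scatter remains open.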